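The source may report more compounds than this note shows. Statements on the series, on what has been measured and on what is new or still open speak of the compounds shown alone.

For the measured compounds named here, compound 1 (`COc1ccc(CSc2nnc(-c3cc(OC)c(OC)c(OC)c3)n2-c2ccc(OC)cc2)cc1`) holds the only true number so far: in a functional assay on HCT-116 cells (Homo sapiens) for inhibition, read by MTT assay, with a stated time of 48 h (a lower number here means a stronger inhibitor, a higher number a weaker inhibitor), compound 1 gives 49600 nM. Compound 2 (`COc1ccc(C(=O)CSc2nnc(-c3cc(OC)c(OC)c(OC)c3)n2-c2ccc(OC)cc2)cc1`) gives > 60000 nM, which is a limit of the assay and not a number. Compound 3 (`COc1ccc(-n2c(SCC(=O)c3ccc(OC)c(O)c3)nnc2-c2cc(OC)c(OC)c(OC)c2)cc1`) has not been measured. Its difference from compound 1 is this: (3-hydroxy-4-methoxyphenyl)carbonyl in place of 4-methoxyphenyl on a saturated chain carbon bound to a sulfur. In words, (3-hydroxy-4-methoxyphenyl)carbonyl takes the place of 4-methoxyphenyl on a saturated chain carbon bound to a sulfur. Going by the values given here, the one measured step that bears on this change also brings in the carbonyl, and it reads an at least 1.2-fold higher number from compound 1 to compound 2 (0.08 log units; that floor lies within the scatter). Among the compounds with values here, no measured compound shows the effect of the hydroxy on the entering group. Within the data shown here, with only that step to go on, no change beyond the scatter is expected in this assay, in either direction. The expected step is a 1.2-fold lower number from compound 1 to compound 3 (0.09 log units; within the scatter). For compound 3 the estimated value is 40000 nM, with an expected range from 8000 nM to 100000 nM.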

Compound 3, half-maximal inhibitory concentration: > 60000 nM
Compound 3 ended at the assay's limit; the forecaster's own chance of this, stated with the estimate: 40%; at least 1.5-fold (0.17 log units) between middle value and limit.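

In this assay, (3-hydroxy-4-methoxyphenyl)carbonyl in place of 4-methoxyphenyl gives an at least 1.2-fold higher number from compound 1 to compound 3 (0.08 log units; that floor lies within the scatter), so the floor of this step does not separate compound 3 from compound 1. Compound 3 gives > 60000 nM, which is a limit of the assay and not a number, so with the hydroxy in place the carbonyl series still yields no true number. The step from compound 2 to compound 3 cannot be read because both compounds end at the same limit: the limit of > 60000 nM in this assay, at which 2 of the 3 values shown sit.

Going by these compounds, how far compound 2 and compound 3 lie beyond that limit remains open, and so does any effect of the hydroxy itself. Also open, on these data alone, is whether an amine in place of the hydroxy, or a longer chain on the sulfur, would give a true number in this assay.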